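The source may report more compounds than this note shows. Statements on the series, on what has been measured and on what is new or still open speak of the compounds shown alone.

Compound 1 `NC(=O)c1c(NC(=O)c2cccc([N+](=O)[O-])c2)sc2c1CCN(Cc1c(Cl)cccc1Cl)C2`: 13500 nM
Compound 2 `NC(=O)c1c(NC(=O)c2ccccc2F)sc2c1CCN(C(=O)Nc1ccccc1Cl)C2`: 49600 nM

In a functional assay on MKN-74 cells (Homo sapiens) for antiproliferative activity, with a stated time of 24 h (on this read-out higher numbers stand for weaker inhibition and lower numbers for stronger inhibition), compound 2 gives 49600 nM, the highest of the two numbers here, while compound 1 gives 13500 nM; the gap between them lies beyond the scatter. Compound 1 and compound 2 differ in two places at once, so their two values cannot be read as the effect of any single change. Compound 3 `NC(=O)c1c(NC(=O)c2cccc([N+](=O)[O-])c2)sc2c1CCN(C(=O)Nc1ccccc1Cl)C2` is derived from compound 2 by 3-nitrophenyl in place of 2-fluorophenyl on a carbonyl carbon. Among the measured compounds shown here, no measured pair shows this change on its own; compound 1 carries the same 3-nitrophenyl group but differs from compound 2 elsewhere as well, so its lower number is only a loose hint. The expectation for compound 3 is a moderate move towards a lower number in this assay, expected as a 1.8-fold lower number from compound 2 to compound 3 (0.25 log units; within the scatter), with wide uncertainty. Compound 3 is estimated at 28000 nM, between 8000 nM and 100000 nM.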

Compound 3, half-maximal inhibitory concentration: 22700 nM
Beside the measured number, compound 3's estimate is 1.2-fold (0.09 log units) above it, and the stated range covers the measured number.
By their numbers in this assay, from the lowest: compounds 1 and 3 (each within the scatter of the next); then compound 2.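

In this assay, among the compounds shown here, putting 3-nitrophenyl in place of 2-fluorophenyl on a carbonyl carbon gives a 2.2-fold lower number from compound 2 to compound 3 (0.34 log units; beyond the scatter), a modest step and the first reading of this change on its own, with the (2-chlorophenyl)carbamoyl group kept on the amine nitrogen in a ring. With the 3-nitrophenyl group held constant, (2-chlorophenyl)carbamoyl in place of 2,6-dichlorobenzyl on that nitrogen gives a 1.7-fold higher number from compound 1 to compound 3 (0.23 log units; within the scatter), so the two groups on the nitrogen cannot be told apart on this read-out. No measurement at hand gives a reason for either step. The compounds shown leave open whether the change on the carbonyl carbon would give a similar step with 2,6-dichlorobenzyl on the nitrogen. They also leave open how a plain phenyl, or a phenyl carrying an amine or a carboxylic acid, would read on that carbonyl carbon.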